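Para-substituted salicyloyl benzamides: cytotoxicity notes

This account rests on a few compounds, and the source may have more. Where it says the series, first, only, none or still open, it means among the compounds named here.

Compound 1 `O=C(NC(=O)c1ccccc1O)c1ccc(F)cc1` is the fluoro member of the series. In an ADME assay on L6 cells (Rattus norvegicus) for cytotoxicity, read by resazurin assay, with a stated time of 72 h (on this read-out higher numbers stand for weaker inhibition and lower numbers for stronger inhibition), compound 1 gives 38 ug/mL, the highest of the two numbers recorded so far. Its nearest neighbour is compound 2 `CCOc1ccc(C(=O)NC(=O)c2ccccc2O)cc1`, which in this assay gives 17 ug/mL. Among the compounds with values here, the single measured step, a 2.2-fold lower number from compound 1 to compound 2 (0.35 log units; beyond the scatter), arises from ethoxy in place of fluoro on an aromatic carbon and is modest but beyond the scatter.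

Compound 3 `CN(C)c1ccc(C(=O)NC(=O)c2ccccc2O)cc1` has not yet been measured in this assay. It differs from compound 1 by dimethylamino in place of fluoro on an aromatic carbon. Within the data shown here, the only step that bears on this change is the one from compound 1 to compound 2, where a larger group entering in place of fluoro at the same place lowered the number by a 2.2-fold lower number from compound 1 to compound 2 (0.35 log units; beyond the scatter). By analogy, a step of similar size and direction is expected here, so compound 3 is estimated at a 1.9-fold lower number from compound 1 to compound 3 (0.28 log units; within the scatter) relative to compound 1. Compound 3 is therefore expected to give about 20 ug/mL in this assay, with a range of 8 ug/mL to 50 ug/mL.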

Compound 3, half-maximal inhibitory concentration: 54 ug/mL
Compound 3: middle estimate off by 2.7-fold (0.43 log units), on the low side, and the stated range ends below it.
By their numbers in this assay, from the lowest: compound 2; then compounds 1 and 3 (each within the scatter of the next).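

In this assay, dimethylamino in place of fluoro gives a 1.4-fold higher number from compound 1 to compound 3 (0.15 log units; within the scatter), so at this aromatic carbon, para to a large group, the entry of a group with more heavy atoms does not by itself move the number beyond the scatter. The same position separates ethoxy from dimethylamino, with a 3.2-fold higher number from compound 2 to compound 3 (0.50 log units; beyond the scatter) for that exchange, and this shows that the step from compound 1 to compound 2 cannot be read as a general result of replacing fluoro with a larger group. Among these three compounds, compound 2 alone stands apart, with its steps to both compound 1 and compound 3 printed as beyond the scatter, and no measurement at hand explains why ethoxy and dimethylamino differ at this position.

Going by these compounds, it remains open whether the lower number belongs to ethoxy specifically or extends to other ether groups, such as methoxy or a longer butoxy chain. On these data alone, it is equally open whether an unsubstituted amine or a diethylamino group at the same place would read with compound 3 or with compound 2, which would show how far the nitrogen-linked groups hold together as a set.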